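Replacing One Aromatic Group on an Amide-Type Nitrogen

This account rests on a few compounds, and the source may have more. Where it says the series, first, only, none or still open, it means among the compounds named here.

Compound 1 `Cc1n[nH]c2c1C(c1ccc(N(C)C)cc1)C(C(=O)NN)=C(N)N2`: 51300 nM
Compound 2 `Cc1n[nH]c2c1C(c1ccc(N(C)C)cc1)C(C(=O)N/N=C/c1ccc(Cl)cc1)=C(N)N2`: 31700 nM

Both compounds were measured in a functional assay on HeLa cells (Homo sapiens) for cytotoxicity, read by MTT assay, with a stated time of 48 h (on this read-out lower numbers stand for stronger inhibition and higher numbers for weaker inhibition), and the values of compound 1 and compound 2 lie within the usual scatter of each other. Neither can therefore be ranked above the other. The next comparison starts from compound 2 and turns to compound 3 `Cc1n[nH]c2c1C(c1ccc(N(C)C)cc1)C(C(=O)N/N=C1/C(=O)Nc3ccccc31)=C(N)N2`, which has not yet been measured. The structural change is a group of 11 heavy atoms (8 carbon, 2 nitrogen, 1 oxygen; one five-membered non-aromatic ring with 1 hetero atom, one six-membered aromatic ring of carbon only) in place of a group of 9 heavy atoms (7 carbon, 1 nitrogen, 1 chlorine; one six-membered aromatic ring of carbon only), on an amide-type nitrogen, and it sits on an amide-type nitrogen whose other neighbour is a carbonyl carbon.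

Within the data shown here, only one measured step involves a change at this nitrogen: a 1.6-fold lower number from compound 1 to compound 2 (0.21 log units; within the scatter). Among the measured compounds shown here, no measured compound carries the entering group, so the data offer no direct precedent for it. Resting on compound 2 and that single step a 1.6-fold lower number from compound 1 to compound 2 (0.21 log units; within the scatter), no change beyond the scatter is expected in this assay. The expected step is a 1.1-fold lower number from compound 2 to compound 3 (0.02 log units; within the scatter).

For compound 3 the estimated value is 30000 nM, with an expected range from 11000 nM to 80000 nM.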

Compound 3, half-maximal inhibitory concentration: 52900 nM
The estimate for compound 3 lay 1.8-fold (0.25 log units) below the measured number; the range from low to high includes it.
By their numbers in this assay, from the lowest: compounds 2, 1 and 3 (each within the scatter of the next).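

At the amide-type nitrogen whose other neighbour is a carbonyl carbon, this assay now gives a reading for a second, differently built group: exchanging the chlorine-bearing group for the one with a five-membered non-aromatic ring with 1 hetero atom gives a 1.7-fold higher number from compound 2 to compound 3 (0.22 log units; within the scatter). Set against the compound with the single nitrogen atom at this place, the same entering group gives a 1.0-fold higher number from compound 1 to compound 3 (0.01 log units; within the scatter), so compounds 1, 2 and 3 all lie within the scatter of one another, and neither larger group separates from that single nitrogen atom on this read-out. There is no independent evidence that bears on why these three numbers lie so close together.

The three compounds leave open whether any group at this nitrogen can produce a step beyond the scatter, for instance a simple amine, a carboxylic acid or a longer alkyl chain. They also leave open whether changing the dimethylamino group or another part of the shared core would matter more than changes at this nitrogen.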